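Swapping dimethylamino for pyrrolidin-1-yl on compound 2

The source may hold more compounds than are shown below. What is called first, only, known or untested is meant among the compounds shown, and "the series" means these compounds.

Compound 1 `Cc1ccc(-c2cc(C(=O)Nc3cccnc3)c3cc(F)ccc3n2)cc1`: 50000 nM
Compound 2 `Cc1ccc(-c2cc(C(=O)NCCN(C)C)c3cc(Cl)ccc3n2)cc1`: 9000 nM

Both numbers come from an ADME assay on MRC5 cells (Homo sapiens) for antiproliferative activity, read by fluorescence and resazurin assay, with a stated time of 68 h; on this read-out higher numbers stand for an effect only at larger amounts of compound and lower numbers for an effect already at smaller amounts. Of the two, compound 2 holds the lower number at 9000 nM, and its gap to compound 1 lies beyond the usual scatter of repeated measurements. Compound 2 therefore shows its effect at smaller amounts of compound.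

Still unmeasured is compound 3 `Cc1ccc(-c2cc(C(=O)NCCN3CCCC3)c3cc(Cl)ccc3n2)cc1`, which keeps the core of compound 2 and changes one group. It carries pyrrolidin-1-yl in place of dimethylamino on a saturated chain carbon, two bonds along the chain from an amide-type nitrogen.

Going by the values given here, no two measured compounds differ in one place only, so the data give no direct measure of what such a swap does in this assay. The expectation starts instead from compound 2 at 9000 nM. The estimated change, a 1.1-fold lower number from compound 2 to compound 3 (0.05 log units; within the scatter), is expected to stay within the scatter, with no clear direction. Compound 3 is estimated at 8000 nM, with an expected range from 3000 nM to 20000 nM.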

Compound 3, half-maximal effective concentration: 7000 nM
Compound 3: the middle estimate sits 1.1-fold (0.06 log units) above what was measured, and the stated range covers the measured number.
By their numbers in this assay, from the lowest: compounds 3 and 2 (each within the scatter of the next); then compound 1.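

In this assay, pyrrolidin-1-yl in place of dimethylamino on a saturated chain carbon, two bonds along the chain from an amide-type nitrogen, gives a 1.3-fold lower number from compound 2 to compound 3 (0.11 log units; within the scatter). Going by these compounds alone, this is the first pair of compounds here that differs in one place only, and it gives a direct reading for this position: a group of 5 heavy atoms with a five-membered non-aromatic ring stands in for a group of 3 heavy atoms with no ring, and the two compounds cannot be told apart on this read-out. No other measurement accompanies this pair, so the data offer no explanation for the result.

The compounds shown leave open whether a piperidin-1-yl or morpholin-4-yl group at this place, or a longer chain carrying the same pyrrolidin-1-yl group, would also stay within the scatter of compound 2. Compound 1, at 50000 nM, differs from the other two compounds in more than one place, so its value cannot be tied to any single group.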